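This account rests on a few compounds, and the source may have more. Where it says the series, first, only, none or still open, it means among the compounds named here.

Of the compounds shown here, three sharing one core have been read in an ADME assay on CEM-SS cells (Homo sapiens) for cytotoxicity, read by XTT assay, with a stated time of 6 days; a lower number here means that less compound is tolerated, a higher number that more compound is tolerated. Compound 1 (`CCCC(=O)OCSc1ccccc1C(=O)NCCC(N)=O`) gives only a limit, > 100 uM. Compound 2 (`CCCC(=O)OCSc1ccccc1C(=O)NCCCCC(N)=O`) gives 51.7 uM, and compound 3 (`CCCC(=O)OCSc1ccccc1C(=O)N(C)CC(N)=O`) gives 55.3 uM. Those last two numbers cannot be told apart, since the data show a 1.1-fold higher number from compound 2 to compound 3 (0.03 log units; within the scatter). Compound 3 therefore stands level with compound 2.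

The next molecule, compound 4 (`CCCC(=O)OCSc1ccccc1C(=O)N(C)CC(=O)N(C)C`), alters only the end of the chain: dimethylamino in place of amino on a carbonyl carbon. In words, dimethylamino takes the place of amino on a carbonyl carbon, so carbamoyl becomes dimethylcarbamoyl.

For the measured compounds named here, no measured step touches this end group. The nearest evidence comes from changes elsewhere in the chain. One is an at least 1.9-fold lower number from compound 1 to compound 2 (0.28 log units; that floor lies within the scatter), and another is an at least 1.8-fold lower number from compound 1 to compound 3 (0.25 log units; that floor lies within the scatter). Both of those are floors, not true sizes. Going by the values given here, the only step between two real numbers is the small one already mentioned, and it involves a different change, so it offers weak guidance.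

Starting from compound 3 at 55.3 uM, no step beyond the scatter is expected in this assay, in either direction. The estimated change is a 1.1-fold lower number from compound 3 to compound 4 (0.04 log units; within the scatter). For compound 4 the expected value is 50 uM, with an estimated range of 22 uM to 100 uM.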

Compound 4, half-maximal toxic concentration: 57.3 uM
Beside the measured number, compound 4's estimate is 1.1-fold (0.06 log units) below it; measured number inside the range.
By their numbers in this assay, from the lowest: compounds 2, 3 and 4 (each within the scatter of the next). At a limit, above all of these: compound 1.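

In this assay, putting dimethylamino in place of amino on a carbonyl carbon gives a 1.0-fold higher number from compound 3 to compound 4 (0.02 log units; within the scatter). For the compounds shown here, this is the first measured change at the end of the chain, and it shows that carbamoyl can become dimethylcarbamoyl, with the one hydrogen-bond donor counted for amino leaving and none entering, without a shift beyond the usual scatter. The wider swap of ((dimethylcarbamoyl)methyl)(methyl)amino in place of (4-carbamoylbutyl)amino on a carbonyl carbon gives a 1.1-fold higher number from compound 2 to compound 4 (0.04 log units; within the scatter), so compounds 2, 3 and 4 cannot be told apart in this read-out, even though their chains differ. Compound 1 gives only a limit, so ((dimethylcarbamoyl)methyl)(methyl)amino in place of (2-carbamoylethyl)amino on a carbonyl carbon gives an at least 1.7-fold lower number from compound 1 to compound 4 (0.24 log units; that floor lies within the scatter), which is a floor and not a true size: the limit of > 100 uM in this assay, at which 1 of the 4 values shown sits.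

Going by these compounds, what a carboxylic acid, or a larger amine such as piperidine, would give on this carbonyl carbon remains open, so the tolerance seen here is known for dimethylamino alone. Also open, on these data alone, is whether methylamino, or dimethylcarbamoyl on a longer chain, would stay level with compound 3 or move away from it.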